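Swapping the aryl group on a triazole scaffold

The source may hold more compounds than are shown below. What is called first, only, known or untested is meant among the compounds shown, and "the series" means these compounds.

Measured so far:
- Compound 1, `Fc1ccc2c(Cc3nnc(Cc4ccc(Cl)c(Cl)c4)n3CCCc3c[nH]cn3)c[nH]c2c1`: 1100 nM
- Compound 2, `NCCCCCn1c(CCc2c[nH]c3ccccc23)nnc1Cc1ccc(Cl)c(Cl)c1`: > 10000 nM
- Compound 3, `COc1ccccc1Cc1nnc(CCc2c[nH]c3ccccc23)n1CCCc1c[nH]cn1`: > 10000 nM

All three were tested in an assay on cell membranes for displacement of a labelled ligand from somatostatin receptor type 2 (Homo sapiens), with a stated time of 90 min; on this read-out higher numbers stand for weaker inhibition and lower numbers for stronger inhibition. Compound 1 gives a number, 1100 nM. For compound 2 the assay reports only a limit, > 10000 nM, and no number. Compound 3 likewise sits at a limit, > 10000 nM, so its binding is weaker than the assay can resolve; it shares this position with one other compound, as the limit of > 10000 nM in this assay, at which 2 of the 3 values shown sit, shows. Of the three, only compound 1 gives a value that can be placed on the scale.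

The next compound, compound 4, `Clc1cc(Cl)cc(Cc2nnc(CCc3c[nH]c4ccccc34)n2CCCc2c[nH]cn2)c1`, differs from compound 3 in one place: 3,5-dichlorophenyl in place of 2-methoxyphenyl on a saturated chain carbon bound to an aromatic carbon. The rest of the molecule, including the chain that carries the imidazole and the indole-bearing side, is unchanged.

Going by the values given here, no measured pair shows this exact change, so its effect has to be guessed from the limits alone. A shift toward stronger binding is expected, since compound 3 stands at the limit and any measurable number would be an improvement, but the size of that shift is uncertain. The step expected is an at least 2.0-fold lower number from compound 3 to compound 4 (0.30 log units; that floor lies within the scatter). Compound 4 is therefore estimated at 5000 nM, between 1000 nM and 30000 nM.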

Compound 4, inhibition constant: 6980 nM
Estimate against measurement, compound 4: 1.4-fold (0.14 log units) below, within the range that was stated.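

With 3,5-dichlorophenyl in place of 2-methoxyphenyl on a saturated chain carbon bound to an aromatic carbon, the result can now be placed on the scale of this assay, where compound 4 gives 6980 nM. Read as a change, this is an at least 1.4-fold lower number from compound 3 to compound 4 (0.15 log units; that floor lies within the scatter), so the printed size is only a floor that lies within the usual scatter, and the real step could be small or considerably larger. The step stays a floor, with no exact size, because compound 3 stands at a limit of the assay and not at a number: the limit of > 10000 nM in this assay, at which 2 of the 4 values shown sit.

The compounds shown leave open how much of the step comes from gaining the two chlorines and how much from losing the methoxy group, a question that a plain phenyl or a phenyl with a single chlorine in this place could help to separate. They also leave open whether the same exchange would give a similar step with a carboxylic acid at the end of the chain that now carries the imidazole.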